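This account rests on a few compounds, and the source may have more. Where it says the series, first, only, none or still open, it means among the compounds named here.

Measured so far in a functional assay on HEp-2 cells (Homo sapiens) for antiproliferative activity, read by MTT assay, with a stated time of 72 h; a lower number here means a stronger inhibitor, a higher number a weaker inhibitor:
compound 1 `Cc1ccc2c(=O)c(CSC(=S)N(C(C)C)C(C)C)coc2c1` — 700 nM
compound 2 `O=c1c(Cl)c(CSC(=S)N2CCOCC2)oc2ccccc12` — 9000 nM

Compound 2 carries the highest number of the two shown in this assay. Its nearest neighbour is compound 1, which gives 700 nM, a gap that lies beyond the usual scatter; the two compounds differ in more than one place, so nothing is drawn from that gap beyond what the two values show.

Compound 3 `O=c1c(Cl)c(CSC(=S)N2CCCC2)oc2ccccc12` is the next compound to be measured. It differs from compound 2 in one place: pyrrolidin-1-yl in place of morpholin-4-yl on a thiocarbonyl carbon. For the measured compounds named here, no pair of measured compounds differing in one place exists in this set, so the size of the step from compound 2 to compound 3 in this assay cannot be read from data; it is expected to be small, in either direction, and most likely not beyond the scatter, with a slight lean toward a lower number.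

Compound 3 is therefore estimated at 6000 nM in this assay, within a range of 2000 nM to 20000 nM, an expected step of a 1.5-fold lower number from compound 2 to compound 3 (0.18 log units; within the scatter).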

Compound 3, half-maximal inhibitory concentration: 600 nM
Beside the measured number, compound 3's estimate is 10-fold (1.00 log units) above it, outside the stated range (below it).
By their numbers in this assay, from the lowest: compounds 3 and 1 (each within the scatter of the next); then compound 2.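

In this assay pyrrolidin-1-yl in place of morpholin-4-yl on a thiocarbonyl carbon gives a 15-fold lower number from compound 2 to compound 3 (1.18 log units; beyond the scatter) and so marks this position as one where a single change, with the rest of the molecule held constant, can shift the number by a large amount. The swap alters two things at once, a six-membered ring with 2 hetero atoms giving way to a five-membered ring with 1 hetero atom, and this one pair cannot separate the loss of the ring oxygen from the change in ring size. Nothing at hand accounts for the size of the step.

Piperidin-1-yl on the same thiocarbonyl carbon would separate those two changes, since it keeps the six-membered ring without the oxygen. Also open, on these data alone, are how an open-chain group such as diethylamino behaves on the core of compound 2 and whether the step carries over to a core without the chlorine, since compound 1 differs from the other two compounds in more than one place.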